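A few compounds are considered here, and "the series" means these few. Any claim that something is new, unique, unknown or untested is made for them only; others in the source may bear on it.

Working notes on the series. In a functional assay on MCF7 cells (Homo sapiens) for inhibition, read by MTT assay, with a stated time of 48 h (a higher number here means a weaker inhibitor of growth, a lower number a stronger inhibitor of growth), compound 1 (`c1cc(N2CCCCC2)nc(Nc2ccc(OCCCN3CCCCC3)cc2)n1`) reads > 30000 nM, which is a limit of the assay and not a number. Within the data shown here, compound 2 (`CC1CCN(c2ccnc(Nc3ccc(OCCCN4CCCCC4)cc3)n2)CC1`) gives 28100 nM, the only actual number so far in this assay.

Compound 3 (`ClC1CCN(c2ccnc(Nc3ccc(OCCCN4CCCCC4)cc3)n2)CC1`) differs from compound 2 by chloro in place of methyl on a saturated ring carbon, 4-methylpiperidin-1-yl to 4-chloropiperidin-1-yl. Among the measured compounds shown here, the one measured step at this ring carbon is an at least 1.0-fold lower number from compound 1 to compound 2 (0.02 log units; that floor lies within the scatter), with methyl in place of hydrogen. No change beyond the scatter has been shown there, so none is expected in this assay. The expected step is a 1.2-fold lower number from compound 2 to compound 3 (0.07 log units; within the scatter), with no firm direction. For compound 3 the estimated value is 24000 nM, with an expected range of 11000 nM to 30000 nM.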

Compound 3, concentration for 50% growth inhibition: > 30000 nM
Compound 3 ended at the assay's limit; the forecaster's own chance of this, stated with the estimate: 35%; middle value at least 1.2-fold (0.09 log units) away from the limit.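

In this assay compound 3 gives > 30000 nM, which is a limit of the assay and not a number. Chloro in place of methyl on this saturated ring carbon gives an at least 1.0-fold higher number from compound 2 to compound 3 (0.02 log units; that floor lies within the scatter), so this change adds a second group beside methyl without a shift beyond the scatter, and the step from compound 1 to compound 3 cannot be read. With hydrogen, methyl and chloro at this ring carbon, no change beyond the scatter has been shown, and the readable window for this position is very narrow: the limit of > 30000 nM in this assay, at which 2 of the 3 values shown sit.

Going by these compounds, it remains open whether any group at this ring carbon can bring the series clearly inside the measurable range. An amine, a hydroxyl or a carboxylic acid there, or a longer chain, would be the next groups to read against compound 2.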